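The source may hold more compounds than are shown below. What is called first, only, known or untested is meant among the compounds shown, and "the series" means these compounds.

Working notes on the series.

Compound 1 `COc1cccc(CNCCCNc2ccnc3cc(-c4ccc(C(C)(C)C)cc4)ccc23)c1O` is measured in a physicochemical assay for solubility, with a stated time of 18 h, at pH 7.4 (on this read-out higher numbers stand for higher solubility and lower numbers for lower solubility), at 32000 nM. Compound 2 `CC(C)(C)c1ccc(-c2ccc3c(NCCCNCc4ccco4)ccnc3c2)cc1` gives 32000 nM in this assay, and compound 3 `c1coc(CNCCCNc2ccnc3cc(CC4CCCCC4)ccc23)c1` gives 4200 nM. On these numbers compound 1 stands level with compound 2 at the digits shown, the two together the highest of the three, with compound 3 furthest from it. The step of no change at the digits printed from compound 1 to compound 2 (within the scatter) shows that changing the group on the saturated chain carbon bound to an amine nitrogen left the read-out unchanged, while the step of a 7.6-fold lower number from compound 2 to compound 3 (0.88 log units; beyond the scatter) shows that replacing the group on the aromatic carbon of the core did shift it.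

Compound 4 `COc1cccc(CNCCCNc2ccnc3cc(Oc4ccc(C(C)(C)C)cc4)ccc23)c1O` differs from compound 1 in 4-(tert-butyl)phenoxy in place of 4-(tert-butyl)phenyl on an aromatic carbon. Among the measured compounds shown here, the change sits at the same aromatic carbon as the one in the step from compound 2 to compound 3, but the group in compound 4 keeps the same ring and inserts only one oxygen, so that step bears on it only loosely. For the measured compounds named here, no measured step covers an insertion of this kind. A step of no more than the scatter is therefore expected, with no clear direction; the estimate for compound 4 in this assay is 32000 nM, range 14000 nM to 64000 nM, meaning an expected step of no change at the digits printed from compound 1 to compound 4 (within the scatter).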

Compound 4, solubility: 14500 nM
Compound 4: middle estimate off by 2.2-fold (0.34 log units), on the high side; the measured number falls inside the stated range.
By their numbers in this assay, from the lowest: compound 3; then compound 4; then compounds 1 and 2 (each within the scatter of the next).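

With 4-(tert-butyl)phenoxy in place of 4-(tert-butyl)phenyl on the aromatic carbon of the core, this assay gives a 2.2-fold lower number from compound 1 to compound 4 (0.34 log units; beyond the scatter), so this position registers a change even when the terminal aromatic ring and its tert-butyl group both stay. Before this, the only change read at this carbon was a 7.6-fold lower number from compound 2 to compound 3 (0.88 log units; beyond the scatter), which exchanged the whole group for cyclohexylmethyl and was read with furan-2-yl on the chain; the new step instead isolates the entry of a single oxygen and is read with 2-hydroxy-3-methoxyphenyl on the chain. Both changes at this carbon lower the number, though two steps on different chains make a thin basis for a pattern, and nothing at hand accounts for the shift with the oxygen.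

Still open, from the compounds shown here alone, is whether a methylene or an amine nitrogen in the place of that oxygen would move the number in the same way. Also open, going by these compounds, is whether the oxygen step holds with furan-2-yl on the chain, where only the phenyl form has a number.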